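The compounds below may be only part of what the source reports. "The series", "measured", "known", "first", "only" and "open" are said of these compounds alone.

Within the data shown here, in a physicochemical assay for solubility, read by HPLC, using the shake flask method, measured as kinetic solubility, with a stated time of 20 h, at pH 6.5, tested at 200 uM (a lower number here means a less soluble compound, a higher number a more soluble compound), compound 1 `O=S(=O)(c1cccc(Nc2ccc3nccc(-c4ccncc4)c3n2)c1)N1CCCCC1` gives 15000 nM as the only true number so far. Compound 2 `NS(=O)(=O)c1cccc(-c2ccc3nccc(-c4cccnc4)c3n2)c1` stands at < 5000 nM as a limit of the assay and not a number. Compound 3 `O=S(=O)(c1cccc(Nc2ccc3nccc(-c4ccncc4)c3n2)c1)N1CCCC1` has pyrrolidin-1-yl in place of piperidin-1-yl on a sulfonyl sulfur and keeps the rest of compound 1 unchanged. Among the measured compounds shown here, no measured pair shows this change, and in this assay no step beyond the usual scatter is expected. The estimated step of a 1.2-fold higher number from compound 1 to compound 3 (0.08 log units; within the scatter) is expected to stay within that scatter. For compound 3 the expected value is 18000 nM with an estimated range from 7000 nM to 45000 nM in this measurement.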

Compound 3, solubility: < 5000 nM
Compound 3 was reported as a limit; the forecaster's own chance of this, stated with the estimate: 15%; middle value at least 3.6-fold (0.55 log units) away from the limit.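

Among these compounds, on a sulfonyl sulfur, pyrrolidin-1-yl in place of piperidin-1-yl gives an at least 3.0-fold lower number from compound 1 to compound 3 (0.47 log units; beyond the scatter) in this assay, so this one change at this position moves the reading beyond the scatter, which no earlier pair could show. Compound 3 stands at < 5000 nM, which is a limit of the assay and not a number. The step therefore marks only a minimum, and its full size cannot be read: the limit of < 5000 nM in this assay, at which 2 of the 3 values shown sit.

As far as these compounds go, what causes the drop stays open. So does how the reading would respond to other groups on that sulfur, such as morpholin-4-yl or an open-chain dimethylamino group.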